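A few compounds are considered here, and "the series" means these few. Any claim that something is new, unique, unknown or untested is made for them only; others in the source may bear on it.

In a functional assay on the whole organism with Mus musculus as the target (on this read-out higher numbers stand for an effect only at larger amounts of compound and lower numbers for an effect already at smaller amounts), the measured compounds are:
Compound 1 `O=Cc1cccn1Nc1ccncc1` gives > 20 mg/kg
Compound 2 `CN(c1ccncc1)n1cccc1C=O` gives > 20 mg/kg

Compound 2 stands at > 20 mg/kg as a limit of the assay, not a number. The evidence so far is the limit of > 20 mg/kg in this assay, at which 2 of the 2 values shown sit, and nothing more. Going by the values given here, the one measured step is a step that the two limits leave unreadable from compound 1 to compound 2 and offers no size to carry over. Compound 3 `CN(c1ccncc1)n1cccc1C#N` differs from compound 2 through cyano in place of formyl on an aromatic carbon in a single change, cyano in place of formyl on an aromatic carbon. No clear step is therefore expected, and the estimated step that the limit leaves unreadable from compound 2 to compound 3 is only a rough figure. Compound 3 is estimated at 30 mg/kg with an expected range from 10 mg/kg to 90 mg/kg and is expected to come out as a limit again.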

Compound 3, dose for half-maximal effect: > 20 mg/kg
Compound 3 ended at the assay's limit (the forecaster's own chance of this, stated with the estimate: 70%); the middle value does not contradict the limit.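

Compound 2 and compound 3 both end at a limit in this assay and not at a number, so the step between them cannot be read. The compounds shown leave open how cyano and formyl truly compare on this read-out.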